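From a carbamoyl end to a chlorophenyl end

The source may report more compounds than this note shows. Statements on the series, on what has been measured and on what is new or still open speak of the compounds shown alone.

Compound 1 `C=C[C@@](C)(/C=C/c1ccc(O)c(CO)c1)CCC=C(C)C` carries hydroxymethyl on an aromatic carbon of the shared core. In a functional assay on SEM cells (Homo sapiens) for cytotoxicity, with a stated time of 72 h (on this read-out lower numbers stand for an effect already at smaller amounts and higher numbers for an effect only at larger amounts of compound), compound 1 gives > 36600 nM, which is a limit and not a number. Compound 2 `C=C[C@@](C)(/C=C/c1ccc(O)c(C=O)c1)CCC=C(C)C` has formyl there and gives 8510 nM, so the change is an at least 4.3-fold lower number from compound 1 to compound 2 (0.63 log units; beyond the scatter). Compound 3 `C=C[C@@](C)(/C=C/c1ccc(O)c(/C=C/C(N)=O)c1)CCC=C(C)C` has 2-carbamoylethenyl instead. Compound 3 gives > 36600 nM, again a limit. Against formyl, that is an at least 4.3-fold higher number from compound 2 to compound 3 (0.63 log units; beyond the scatter), whereas against hydroxymethyl it is a step that the two limits leave unreadable from compound 1 to compound 3.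

Compound 4 `C=C[C@@](C)(/C=C/c1ccc(O)c(/C=C/c2ccc(Cl)cc2)c1)CCC=C(C)C` has 4-chlorophenyl in place of carbamoyl on a double-bonded chain carbon bound to a double-bonded chain carbon. Within the data shown here, no measured step makes this exact exchange. The nearest guide is compound 2, whose an at least 4.3-fold higher number from compound 2 to compound 3 (0.63 log units; beyond the scatter) shows that changes on this aromatic carbon can move the number beyond the scatter. A modest shift is therefore expected, and its size stays uncertain with only a limit to start from. The expected change is an at least 3.0-fold lower number from compound 3 to compound 4 (0.48 log units; beyond the scatter), towards a lower number. For compound 4 the estimated value is 12000 nM, with an expected range from 4000 nM to 36000 nM.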

Compound 4, half-maximal effective concentration: > 36600 nM
Compound 4: no number, only a limit (the forecaster's own chance of this, stated with the estimate: 30%); middle value at least 3.0-fold (0.48 log units) from the limit.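

In this assay compound 4 also gives only a limit, so replacing carbamoyl with 4-chlorophenyl does not produce a measurable value. Against formyl, the 2-(4-chlorophenyl)ethenyl group gives an at least 4.3-fold higher number from compound 2 to compound 4 (0.63 log units; beyond the scatter), so this group and 2-carbamoylethenyl, despite their very different ends, both fail to keep the effect seen with compound 2. The steps from compound 3 and from compound 1 to compound 4 cannot be read, and compound 2 remains the only compound here with a real number, the others all sitting at the same limit: the limit of > 36600 nM in this assay, at which 3 of the 4 values shown sit.

As far as these compounds go, how far the true values of compound 1, compound 3 and compound 4 lie beyond that limit stays unknown. From the compounds shown here alone, it also stays open whether an acetyl group or a carboxylic acid on this aromatic carbon would give a value like that of compound 2.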